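This account rests on a few compounds, and the source may have more. Where it says the series, first, only, none or still open, it means among the compounds named here.

Measured in a functional assay on PLC-PRF-5 cells (Homo sapiens) for inhibition, read by MTT assay, with a stated time of 72 h; a lower number here means a stronger inhibitor, a higher number a weaker inhibitor:
- compound 1 `Nc1ncnc2c1c(-c1cnc3[nH]ccc3c1)nn2CCCCCCCCC(=O)NO` gives 14900 nM
- compound 2 `Nc1ncnc2c1c(-c1cnc3[nH]ccc3c1)nn2CCCCCCCCCC(=O)NO` gives 34200 nM
- compound 3 `Nc1nc2cc(-c3nn(CCCCC(=O)NO)c4ncnc(N)c34)ccc2o1` gives 29600 nM

Compound 3, at 29600 nM, lies within the usual scatter of both other compounds, so no order can be read between it and either of them. The next structure is compound 4 `CNC(=O)CCCCCCCn1nc(-c2ccc3oc(N)nc3c2)c2c(N)ncnc21`. The change from compound 3 is 3-(methylcarbamoyl)propyl in place of hydroxycarbamoyl on a saturated chain carbon, four bonds along the chain from an aromatic nitrogen. In words, 3-(methylcarbamoyl)propyl stands in place of hydroxycarbamoyl on a saturated chain carbon, four bonds along the chain from an aromatic nitrogen.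

Within the data shown here, only one measured step is available, a 2.3-fold higher number from compound 1 to compound 2 (0.36 log units; beyond the scatter). It is modest, it keeps the hydroxycarbamoyl group, and it sits on a core that differs from that of compound 3. It therefore offers a weak guide to the chain part of the change. Among the measured compounds shown here, no measured compound shows what happens when hydroxycarbamoyl is lost, so that part remains open. A small move towards a higher number in this assay is the working expectation, though a larger one cannot be excluded. The expected step is a 1.4-fold higher number from compound 3 to compound 4 (0.13 log units; within the scatter). For compound 4 the estimated value is 40000 nM, with an expected range from 13000 nM to 120000 nM.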

Compound 4, half-maximal inhibitory concentration: 30500 nM
The estimate for compound 4 lay 1.3-fold (0.12 log units) above the measured number, and the stated range covers the measured number.
By their numbers in this assay, from the lowest: compounds 1, 3, 4 and 2 (each within the scatter of the next, the first and the last beyond it).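

In this assay, putting 3-(methylcarbamoyl)propyl in place of hydroxycarbamoyl on a saturated chain carbon, four bonds along the chain from an aromatic nitrogen, gives a 1.0-fold higher number from compound 3 to compound 4 (0.01 log units; within the scatter), so compound 3 and compound 4 cannot be told apart here. This pair is the only one shown in which hydroxycarbamoyl is absent from one member, whereas the earlier step, a 2.3-fold higher number from compound 1 to compound 2 (0.36 log units; beyond the scatter), kept that group on both sides and on a different core; at this position, then, losing hydroxycarbamoyl while gaining the longer 3-(methylcarbamoyl)propyl leaves the read-out within the scatter. No supporting measurement is available to account for this result.

The change alters the chain end and the chain length together, so the pair cannot separate the contribution of each, and a matching effect of opposite sign cannot be ruled out. A longer chain ending in hydroxycarbamoyl on the core of compound 3 would address this, as would a carboxylic acid at the end of the chain of compound 4.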